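Removing the 4-methoxybenzyl group from the ring nitrogen

The source may hold more compounds than are shown below. What is called first, only, known or untested is meant among the compounds shown, and "the series" means these compounds.

Compound 2 `COc1ccc(Cn2nc(-c3ccccc3)c3cc(C(=N)Nc4cccc(C(F)(F)F)c4)nc(Nc4cc(OC)c(OC)c(OC)c4)c32)cc1` stands at the limit of a functional assay on MDA-MB-231 cells (Homo sapiens) for cytotoxicity, read by MTT assay, with a stated time of 72 h; a higher number here means a weaker inhibitor, a lower number a stronger inhibitor: compound 2 gives > 50000 nM, which is a limit of the assay and not a number. Compound 1 `COc1cc(Nc2nc(C(=N)Nc3ccccc3)cc3c(-c4ccccc4)n[nH]c23)cc(OC)c1OC`, which carries hydrogen on the same ring nitrogen and a plain phenyl on the amidine, gives 4500 nM in this assay. Compound 3 `COc1cc(Nc2nc(C(=N)Nc3cccc(C(F)(F)F)c3)cc3c(-c4ccccc4)n[nH]c23)cc(OC)c1OC` has not been measured. It differs from compound 2 by hydrogen in place of 4-methoxybenzyl on an aromatic nitrogen, the amidine aryl with its trifluoromethyl group kept. With only one measured point at the limit (the limit of > 50000 nM in this assay, at which 1 of the 2 values shown sits), the step cannot be sized from the data, but the free ring nitrogen is the feature compound 3 shares with compound 1, whose value stands well below that limit. Compound 3 is therefore expected to gain strongly, with the step of an at least 10-fold lower number from compound 2 to compound 3 (1.00 log units; beyond the scatter) running toward a measurable value. Compound 3 is estimated at 5000 nM, in the range 1500 nM to 20000 nM.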

Compound 3, half-maximal inhibitory concentration: 7600 nM
Estimate against measurement, compound 3: 1.5-fold (0.18 log units) below; low and high end bracket the measured number.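

In this assay compound 2 stands at a limit of the assay and not at a number, so its step can only be read as a bound: the limit of > 50000 nM in this assay, at which 1 of the 3 values shown sits.

With the amidine aryl and its trifluoromethyl kept, hydrogen in place of 4-methoxybenzyl on the aromatic nitrogen gives an at least 6.5-fold lower number from compound 2 to compound 3 (0.81 log units; beyond the scatter), which isolates this position as a change that matters in this assay. Trifluoromethyl in place of hydrogen on an aromatic carbon gives a 1.7-fold higher number from compound 1 to compound 3 (0.23 log units; within the scatter), so this substituent does not separate the pair, and compound 1 and compound 3, both with hydrogen on the ring nitrogen, give measurable values.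

On these data alone, it remains open whether a small group on that nitrogen, such as methyl or ethyl, or a plain benzyl without the methoxy, keeps a measurable value. Also open, as far as these compounds go, is how an amine on the amidine aryl would read in place of trifluoromethyl.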